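Methylamino to ethylamino on two benzophenone cores

A few compounds are considered here, and "the series" means these few. Any claim that something is new, unique, unknown or untested is made for them only; others in the source may bear on it.

Compound 1 `CNCC(=O)Nc1cc(OC)ccc1C(=O)c1ccc(OC)c2c1OC(C)(C)C=C2` and compound 2 `CCNCC(=O)Nc1cc(OC)ccc1C(=O)c1ccc(OC)c2c1OC(C)(C)C=C2` share one core; compound 3 `CNCC(=O)Nc1cc(OC)ccc1C(=O)c1cc(OC)c(OC)c(OC)c1` and compound 4 `CCNCC(=O)Nc1cc(OC)ccc1C(=O)c1cc(OC)c(OC)c(OC)c1` share another. The difference between the two cores is not broken down here. In a functional assay on MCF7 cells (Homo sapiens) for antiproliferative activity, read by MTT assay, with a stated time of 48 h (on this read-out higher numbers stand for weaker inhibition and lower numbers for stronger inhibition), compound 1 gives 820 nM, compound 2 gives 5200 nM and compound 3 gives 550 nM. The change from compound 1 to compound 2 is methyl in place of hydrogen on a saturated chain carbon bound to an amine nitrogen, and it made the step of a 6.3-fold higher number from compound 1 to compound 2 (0.80 log units; beyond the scatter). Compound 4 carries the same change on the other core, (methyl in place of hydrogen on a saturated chain carbon bound to an amine nitrogen), with the place the same. Within the data shown here, because a 6.3-fold higher number from compound 1 to compound 2 (0.80 log units; beyond the scatter) is the only step of this kind known, the step from compound 3 to compound 4 in this assay is expected to be of similar size, a 6.0-fold higher number from compound 3 to compound 4 (0.78 log units; beyond the scatter). For compound 4 the expected value is 3300 nM, with a range from 1200 nM to 9000 nM.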

Compound 4, half-maximal inhibitory concentration: 1050 nM
Estimate against measurement, compound 4: 3.1-fold (0.50 log units) above; the whole stated range lies above it.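

Methylamino to ethylamino does not carry a fixed step size from one core to the other in this assay: on the second core it gives a 1.9-fold higher number from compound 3 to compound 4 (0.28 log units; within the scatter), which stays within the scatter. The two steps differ by more than the scatter of two such steps allows: the same change on two cores in this assay, a 6.3-fold higher number (0.80 log units; beyond the scatter) from compound 1 to compound 2 and a 1.9-fold higher number (0.28 log units; within the scatter) from compound 3 to compound 4, 3.3-fold (0.52 log units) apart, beyond the scatter of two such steps. With a single pair on each core, this shows that the step depends on the core, but not which feature of the core matters or how the change would behave on any further core.

Open, as far as these compounds go, is which part of the difference between the two cores sets the step size. Also open, from the compounds shown here alone, is whether a propylamino or a dimethylamino group would show the same core dependence.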